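Benzylamino for the oxanylmethylsulfanyl group on compound 3

The source may report more compounds than this note shows. Statements on the series, on what has been measured and on what is new or still open speak of the compounds shown alone.

In a functional assay on MV4-11 cells (Homo sapiens) for antiproliferative activity, read by CellTiter-Glo, with a stated time of 72 h (on this read-out lower numbers stand for stronger inhibition of growth and higher numbers for weaker inhibition of growth), compound 1 `Fc1cc(-c2csc(NCC3CCOCC3)n2)c(Cl)cn1` gives > 10000 nM, which is a limit of the assay and not a number. Compound 2 `O=C(Nc1cc(-c2csc(NCC3CCOCC3)n2)c(Cl)cn1)c1ccc(F)cc1` gives 550 nM. Going by the values given here, compound 3 `COCCN[C@H]1CC[C@H](Nc2cc(-c3csc(SCC4CCOCC4)n3)c(Cl)cn2)CC1` gives 340 nM, and this value lies within the scatter of the one for compound 2.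

Compound 4 `COCCN[C@H]1CC[C@H](Nc2cc(-c3csc(NCc4ccccc4)n3)c(Cl)cn2)CC1` carries benzylamino in place of ((oxan-4-yl)methyl)sulfanyl on an aromatic carbon of a five-membered aromatic ring with 1 nitrogen and 1 sulfur: benzylamino in place of ((oxan-4-yl)methyl)sulfanyl on an aromatic carbon.

Among the compounds with values here, the one measured step, an at least 18-fold lower number from compound 1 to compound 2 (1.25 log units; beyond the scatter), is large, but it lies on another ring of the core and does not carry over to this change. Within the data shown here, no measured step covers a change on the five-membered ring. The nearest guide is compound 2, which has an amino link on that carbon but also differs elsewhere, at 550 nM. The expectation in this assay therefore stays close to compound 3 at 340 nM, with a wide margin on both sides. The expected step is a 1.4-fold lower number from compound 3 to compound 4 (0.13 log units; within the scatter), not beyond the scatter. Compound 4 is estimated at 250 nM, with an expected range from 60 nM to 1000 nM.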

Compound 4, concentration for 50% growth inhibition: 330 nM
For compound 4 the middle estimate is 1.3-fold (0.12 log units) below the measured one; the range from low to high includes it.
By their numbers in this assay, from the lowest: compounds 4, 3 and 2 (each within the scatter of the next). At a limit, above all of these: compound 1.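

In this assay, going by these compounds alone, benzylamino in place of ((oxan-4-yl)methyl)sulfanyl, on an aromatic carbon of the five-membered aromatic ring with 1 nitrogen and 1 sulfur, gives a 1.0-fold lower number from compound 3 to compound 4 (0.01 log units; within the scatter), and this is the only measured step at this position. The exchange replaces a six-membered non-aromatic ring with a six-membered aromatic ring of carbon only, and a sulfur link with an amino link that adds a hydrogen-bond donor, yet the read-out does not separate the two compounds, so this position accepts both groups on the shared core of compound 3 and compound 4. No measured property in the data bears on this step, so the flat result has no explanation here.

The link and the ring changed together, so the step cannot say whether each change alone is silent or whether the two offset each other; benzylsulfanyl, which pairs the sulfur link with the aromatic ring, would separate them. Also open, as far as these compounds go, is how far the position accepts other groups in this assay, such as phenethylamino as a longer chain, or a benzylamino carrying a carboxylic acid or a dimethylamino group.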